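Swapping a trifluoromethyl for a fluorinated isopropyl group

The source may report more compounds than this note shows. Statements on the series, on what has been measured and on what is new or still open speak of the compounds shown alone.

Of the compounds shown here, two have been measured in an assay on isolated protein for inhibition of protein kinase C theta type (Homo sapiens), read by TR-FRET, with a stated time of 2 h; a higher number here means a weaker inhibitor, a lower number a stronger inhibitor. Compound 1, `N#Cc1cnc(NCc2cnccc2C(F)(F)F)cc1N[C@H]1CC[C@@H](C(N)=O)CC1`, carries a carboxamide on its saturated ring and a pyridine bearing the trifluoromethyl group; in this assay compound 1 gives 7 nM. Compound 2, `N#Cc1cnc(NCc2cncnc2C(F)(F)F)cc1N[C@H]1CC[C@@H](O)CC1`, instead carries a hydroxyl on the saturated ring and a pyrimidine bearing the trifluoromethyl group; in this assay compound 2 gives 450 nM, the highest of the two numbers, and the gap to compound 1 lies well beyond the scatter. Going by the values given here, compound 1 and compound 2 differ in two places at once, so the two values show only that both changes together matter, not how much each contributes.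

Compound 3, `CC(C)(F)c1ncncc1CNc1cc(N[C@H]2CC[C@@H](O)CC2)c(C#N)cn1`, changes compound 2 in one place: 1-fluoro-1-methylethyl in place of trifluoromethyl on an aromatic carbon. Among the compounds with values here, no measured pair tells how such a swap plays out, so the step is expected to be small, most likely none beyond the scatter; the expected step is a 1.3-fold lower number from compound 2 to compound 3 (0.11 log units; within the scatter). Compound 3 is therefore estimated to give about 350 nM, with a range from 90 nM to 1400 nM.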

Compound 3, half-maximal inhibitory concentration: 32 nM
Compound 3: the middle estimate sits 11-fold (1.04 log units) above what was measured, outside the stated range (below it).
By their numbers in this assay, from the lowest: compound 1; then compound 3; then compound 2.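

Putting 1-fluoro-1-methylethyl in place of trifluoromethyl, on this aromatic carbon next to the ring nitrogen, gives in this assay a 14-fold lower number from compound 2 to compound 3 (1.15 log units; beyond the scatter), so this position responds strongly to the choice of group. The two groups have the same count of heavy atoms, and neither has hydrogen-bond donors, hydrogen-bond acceptors or a net charge, so these counts do not predict the step; what changes is the mix of carbon and fluorine atoms. Nothing measured here accounts for the step.

The compounds shown leave open whether the remaining fluorine is needed, and a plain isopropyl group or a cyclopropyl ring at this position would test that. They also leave open whether the same swap would give a similar step on compound 1, which has a carboxamide on its saturated ring; compound 1 and compound 3 differ in more than one place, so their values alone cannot answer this.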